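A few compounds are considered here, and "the series" means these few. Any claim that something is new, unique, unknown or untested is made for them only; others in the source may bear on it.

Measured compounds:
compound 1, `Cn1cncc1CN1CC(N(CC2CCN(C(=O)C(C)(C)C)CC2)S(=O)(=O)c2ccccn2)Cc2cc(C#N)ccc21`, in an ADME assay on Caco-2 cells (Homo sapiens) for permeability, in the apical to basolateral direction; on this read-out higher numbers stand for higher permeability and lower numbers for lower permeability: 0.5 10^-6 cm/s
compound 2, `CC(=O)N1CCC(CN(C2Cc3cc(C#N)ccc3N(Cc3cncn3C)C2)S(=O)(=O)c2ccccn2)CC1`, in this assay: 0.5 10^-6 cm/s
compound 3, `CCS(=O)(=O)N1CCC(CN(C2Cc3cc(C#N)ccc3N(Cc3cncn3C)C2)S(=O)(=O)c2ccccn2)CC1`, in this assay: 0.1 10^-6 cm/s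

Compound 3 stands lowest of the three numbers in this assay. The two steps into it are alike in size: a 5.0-fold lower number from compound 1 to compound 3 (0.70 log units; beyond the scatter) and a 5.0-fold lower number from compound 2 to compound 3 (0.70 log units; beyond the scatter). Compound 1 and compound 2, which carry (tert-butyl)carbonyl and acetyl on the ring nitrogen, show no change at the digits printed from compound 1 to compound 2 (within the scatter), so the two acyl groups cannot be told apart on this read-out.

Compound 4, `Cn1cncc1CN1CC(N(CC2CCN(C(=O)C3CC3)CC2)S(=O)(=O)c2ccccn2)Cc2cc(C#N)ccc21`, is the next member. It differs from compound 3 as follows: cyclopropylcarbonyl in place of ethylsulfonyl on an amine nitrogen in a ring.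

Within the data shown here, the steps that bear on this change are the two into compound 3, both in which an ethylsulfonyl took the place of a carbonyl-bearing group on the same ring nitrogen and both modest lowerings beyond the scatter. The step to compound 4 runs the other way, bringing a carbonyl-bearing group back onto that nitrogen; the two acyl groups measured so far were indistinguishable, so a cyclopropylcarbonyl is expected to behave like them. Compound 4 is therefore expected to show a rise of about that size, a 5.0-fold higher number from compound 3 to compound 4 (0.70 log units; beyond the scatter). The estimate for compound 4 in this assay is 0.5 10^-6 cm/s, with a range from 0.2 10^-6 cm/s to 1.2 10^-6 cm/s.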

Compound 4, apparent permeability: 0.5 10^-6 cm/s
Compound 4: middle estimate and measured number agree at the digits printed; low and high end bracket the measured number.
By their numbers in this assay, from the lowest: compound 3; then compounds 1, 2 and 4 (each within the scatter of the next).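

In this assay, a third carbonyl-bearing group on the amine nitrogen in the ring undoes the lowering seen with ethylsulfonyl (a 5.0-fold higher number from compound 3 to compound 4 (0.70 log units; beyond the scatter)), so that lowering is not tied to the two earlier acyl groups alone. The cyclopropylcarbonyl compound also sits with those acyl compounds (no change at the digits printed from compound 2 to compound 4 (within the scatter); no change at the digits printed from compound 1 to compound 4 (within the scatter)), which means that methyl, tert-butyl and cyclopropyl on the carbonyl carbon cannot be told apart on this read-out, and among the four compounds only compound 3 stands apart. Nothing available here accounts for the gap between the ethylsulfonyl and carbonyl-bearing groups at this nitrogen.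

Among these compounds, with ethylsulfonyl as the single sulfonyl example, it remains open whether a methylsulfonyl or cyclopropylsulfonyl group on the same nitrogen would stay with compound 3 or move towards the acyl compounds. As far as these compounds go, it is also open whether the flat response among the acyl groups would hold for a carbonyl group carrying an amine or a carboxylic acid, or for a urea at this nitrogen.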